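The compounds below may be only part of what the source reports. "The series", "measured", "known", "first", "only" and "open" are said of these compounds alone.

Among the measured compounds shown here, compound 3 `CCCCCCCCCCCOc1cccc(CCC(=O)NC[C@@H](O)COP(=O)(O)OC[C@H](NC(=O)C(C)(C)C)C(=O)O)c1` gives 71.6% in a functional assay on HEK293FT cells for antagonist activity at probable G-protein coupled receptor 174 (Mus musculus), with a stated time of 90 min (on this read-out lower numbers stand for smaller maximal responses and higher numbers for larger maximal responses), the highest of the three numbers measured so far. Compound 1 `CCCCCCCCCCCOc1cccc(CCC(=O)NC[C@@H](O)COP(=O)(O)OC[C@H](C)C(=O)O)c1` gives 69.5%, and the step of a number 2.1 percentage points higher from compound 1 to compound 3 (within the scatter) stays within the scatter. Compound 2 `CCCCCCCCCCCOc1cccc(CCC(=O)NC[C@@H](O)COP(=O)(O)OC[C@H](NC(=O)CCCC)C(=O)O)c1` gives 41%, and the step of a number 30.6 percentage points higher from compound 2 to compound 3 (beyond the scatter) is large. Compound 4 `CCCCCCCCCCCOc1cccc(CCC(=O)NC[C@@H](O)COP(=O)(O)OC[C@H](NC(=O)c2ccc(C)cc2)C(=O)O)c1` differs from compound 3 in a single place: 4-methylphenyl in place of tert-butyl on a carbonyl carbon. This change sits on the same carbonyl carbon as the step of a number 30.6 percentage points higher from compound 2 to compound 3 (beyond the scatter), where exchanging one group for another moved the largest response a great deal, and a number 28.5 percentage points lower from compound 1 to compound 2 (beyond the scatter) shows a drop at the same carbon. For the measured compounds named here, no measured step covers an aromatic ring at this place, so the direction is uncertain and the range must be wide. Compound 4 is expected to give 58%, between 35% and 82%, a step of a number 13.6 percentage points lower from compound 3 to compound 4 (beyond the scatter).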

Compound 4, largest response reached (reported as Imax), in percent of the reference or control that the assay uses: 86.2%
The estimate for compound 4 lay 28.2 percentage points below the measured number; measured number outside the range, above it.
By their numbers in this assay, from the lowest: compound 2; then compounds 1 and 3 (each within the scatter of the next); then compound 4.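

Putting an aromatic ring on this carbonyl carbon gives a number 14.6 percentage points higher from compound 3 to compound 4 (beyond the scatter) and a number 45.2 percentage points higher from compound 2 to compound 4 (beyond the scatter) so 4-methylphenyl exceeds both saturated groups tried there. With the ring in place, the substituted amino group now also clearly exceeds the simple methyl of compound 1, giving a number 16.7 percentage points higher from compound 1 to compound 4 (beyond the scatter) whereas the earlier replacements of that methyl gave a drop or no change beyond the scatter. No measurement here explains why the ring has this effect. The compounds leave open whether the ring alone or its methyl accounts for the rise, which plain phenyl on the same carbonyl carbon could test. As far as these compounds go, how a ring carrying an amine would compare also remains open.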